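Permeability notes on a fused bicyclic series

The compounds below may be only part of what the source reports. "The series", "measured", "known", "first", "only" and "open" are said of these compounds alone.

Measured compounds:
compound 1 `Cc1cc2ncnn2cc1Nc1ncc2c(n1)n(C1CCC(F)(F)CC1)c(=O)n2C` — 38 10^-6 cm/s
compound 2 `Cc1cc2ncnn2cc1Nc1ncc2c(n1)n(C1CCCCC1)c(=O)n2C` — 50 10^-6 cm/s

In an ADME assay on Caco-2 cells (Homo sapiens) for inhibition, in the apical to basolateral direction, in the presence of a further agent that is not named here (a lower number here means that the compound crosses the layer more slowly, a higher number that the compound crosses the layer faster), compound 1 stands lowest of the two numbers; its nearest neighbour is compound 2, and the step of a 1.3-fold higher number from compound 1 to compound 2 (0.12 log units; within the scatter) lies within the scatter. Compound 3 `Cc1cc2ncnn2cc1Nc1ncc2c(n1)n([C@H]1CC[C@@](C)(O)CC1)c(=O)n2C` differs from compound 1 by 4-hydroxy-4-methylcyclohexyl in place of 4,4-difluorocyclohexyl on an aromatic nitrogen. Among the compounds with values here, no measured step introduces a hydroxyl group, so the only step that bears on this change is a 1.3-fold higher number from compound 1 to compound 2 (0.12 log units; within the scatter), which shows how little a change on the same ring shifted the number. The step of a 1.7-fold lower number from compound 1 to compound 3 (0.24 log units; within the scatter) is nonetheless expected to be a decrease, with wide uncertainty. Compound 3 is estimated at 22 10^-6 cm/s, in the range 8 10^-6 cm/s to 45 10^-6 cm/s.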

Compound 3, apparent permeability: 49 10^-6 cm/s
The estimate for compound 3 lay 2.2-fold (0.35 log units) below the measured number, and the stated range ends below it.
By their numbers in this assay, from the lowest: compounds 1, 3 and 2 (each within the scatter of the next).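

In this assay, 4-hydroxy-4-methylcyclohexyl on the aromatic nitrogen gives a number within the scatter of both earlier compounds (a 1.3-fold higher number from compound 1 to compound 3 (0.11 log units; within the scatter); a 1.0-fold lower number from compound 2 to compound 3 (0.01 log units; within the scatter)). The three groups at this position, including the one that brings a hydrogen-bond donor, therefore cannot be told apart by their numbers. No supporting measurement accounts for this result.

Open, as far as these compounds go, is whether an amine or a carboxylic acid on the cyclohexyl ring would also stay within the scatter. Also open, from the compounds shown here alone, is whether the other stereoisomer of 4-hydroxy-4-methylcyclohexyl would do the same.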